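The source may hold more compounds than are shown below. What is called first, only, known or untested is meant among the compounds shown, and "the series" means these compounds.

- compound 1 `COC(=O)C[C@@H]1C[C@@H](O)[C@H](C)[C@H](c2ccccc2)N1`: 6500 nM
- compound 2 `COC(=O)C[C@H]1C[C@@H](O)[C@@H](C)[C@@H](c2ccc(F)cc2)N1`: 19800 nM
- compound 3 `COC(=O)C[C@H]1C[C@H](O)[C@@H](C)[C@@H](c2ccc(F)cc2)N1`: 17400 nM

In a functional assay on HeLa cells (Homo sapiens) for cytotoxicity, read by MTT assay (on this read-out lower numbers stand for stronger inhibition and higher numbers for weaker inhibition), compound 1 gives the lowest number of the three, and its gaps to compound 2 and compound 3 both lie beyond the scatter. Compound 4 `COC(=O)C[C@H]1C[C@H](O)[C@H](C)[C@@H](c2ccccc2)N1` has the same connectivity as compound 1, and only its spatial arrangement changes: the two compounds have the same atoms and bonds and differ only in configuration as drawn: 3 of 4 stereo elements differ; a stereocentre at a saturated ring carbon is drawn S in compound 1 and R in compound 4; a stereocentre at a saturated ring carbon is drawn R in compound 1 and S in compound 4; a stereocentre at a saturated ring carbon is drawn R in compound 1 and S in compound 4. Among the measured compounds shown here, one measured step bears on this, given the fact that compounds 2 and 3 differ only in the configuration as drawn: a 1.1-fold lower number from compound 2 to compound 3 (0.06 log units; within the scatter). That step changes a single stereocentre, whereas three change here, so it offers only limited guidance. No step beyond the scatter is therefore expected in this assay, though the uncertainty is wide. The estimated step is a 1.2-fold higher number from compound 1 to compound 4 (0.09 log units; within the scatter). Compound 4 is expected at 8000 nM, within an estimated range of 3500 nM to 20000 nM.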

Compound 4, half-maximal inhibitory concentration: 41100 nM
The estimate for compound 4 lay 5.1-fold (0.71 log units) below the measured number; measured number outside the range, above it.
By their numbers in this assay, from the lowest: compound 1; then compounds 3 and 2 (each within the scatter of the next); then compound 4.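

In this assay, the shared core proves sensitive to its spatial arrangement, with a 6.3-fold higher number from compound 1 to compound 4 (0.80 log units; beyond the scatter). Among the compounds shown here, the earlier pair showed no such sensitivity, with a 1.1-fold lower number from compound 2 to compound 3 (0.06 log units; within the scatter), but only one stereocentre changes there, whereas three change together here. No atom or bond differs, so this step reflects spatial arrangement alone: the fact that compounds 1 and 4 differ only in the configuration as drawn

Which of the three stereocentres carries the step stays open. So does how a carboxylic acid or an amide in place of the methyl ester would read on either arrangement.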